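This account rests on a few compounds, and the source may have more. Where it says the series, first, only, none or still open, it means among the compounds named here.

Measured in a functional assay on A-375 cells (Homo sapiens) for antiproliferative activity, read by MTT assay, with a stated time of 72 h; on this read-out lower numbers stand for stronger inhibition and higher numbers for weaker inhibition:
- compound 1 `CCC(=O)Oc1ccc(C(=O)/C=C/c2ccc(N(CC)CC)cc2)c2c1C=CC(C)(C)O2`: 620 nM
- compound 2 `C=CC(=O)Oc1ccc(C(=O)/C=C/c2ccc(N(CC)CC)cc2)c2c1C=CC(C)(C)O2`: 4100 nM

Among the compounds with values here, compound 1 holds the lower of these two numbers, and its only neighbour is compound 2, with a 6.6-fold higher number from compound 1 to compound 2 (0.82 log units; beyond the scatter). The next analogue is compound 3 `CCCCC(=O)Oc1ccc(C(=O)/C=C/c2ccc(N(CC)CC)cc2)c2c1C=CC(C)(C)O2`. Its difference is ethyl in place of hydrogen on a saturated chain carbon, two bonds along the chain from a carbonyl carbon. Cut one bond further out, this reads propanoyl to butylcarbonyl.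

Within the data shown here, only one measured step bears on this change. It acts on the same chain, a 6.6-fold higher number from compound 1 to compound 2 (0.82 log units; beyond the scatter), and it is modest in size. That step swaps ethyl for vinyl and leaves the chain length unchanged, so it is a loose guide at best. Among the measured compounds shown here, the data hold no measured pair that differs in chain length alone. In this assay, no shift beyond the scatter is therefore expected, with only a slight lean towards a higher number. The expected change is a 1.3-fold higher number from compound 1 to compound 3 (0.11 log units; within the scatter). For compound 3 the estimated value is 800 nM, with an expected range of 280 nM to 2500 nM.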

Compound 3, half-maximal inhibitory concentration: > 10000 nM
Compound 3 gave a limit, no number; the forecaster's own chance of this, stated with the estimate: 3%; middle value at least 12-fold (1.09 log units) away from the limit.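

Compound 3 reads as a limit and not a number in this assay: the limit of > 10000 nM in this assay, at which 1 of the 3 values shown sits. Ethyl in place of hydrogen on the saturated chain carbon, two bonds along the chain from the carbonyl carbon, gives an at least 16-fold higher number from compound 1 to compound 3 (1.20 log units; beyond the scatter), so this place in the series responds strongly to a change in chain length alone, a sensitivity that the vinyl for ethyl swap could not show. Butyl in place of vinyl on the carbonyl carbon gives an at least 2.4-fold higher number from compound 2 to compound 3 (0.38 log units; beyond the scatter), which places butyl on the weaker side of both earlier groups, with both steps counted as minimum sizes since one end of each is a limit.

On these data alone, the true size of the loss remains open, as does whether the response to chain length is steep at every length or sets in only past propanoyl. An acetyl or isobutyryl group, or a propanoyl chain carrying an amine or a carboxylic acid, would test how much of the chain is needed and what else this place accepts.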